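The source may hold more compounds than are shown below. What is called first, only, known or untested is meant among the compounds shown, and "the series" means these compounds.

Working notes on the series, read in a functional assay on the whole organism (strain Kunming) with Mus musculus as the target, with a stated time of 0.5 h; a lower number here means that less compound is needed, a higher number that more compound is needed for the effect. Compound 1 `COc1cc(OC)c(OC)cc1/C=C/COC(=O)/C=C/c1ccc(Br)cc1` gives > 300 mg/kg, which is a limit and not a number. Compound 1 stands at the limit of > 300 mg/kg in this assay, at which 2 of the 3 values shown sit. Compound 2 `COc1cc(OC)c(OC)cc1/C=C/COC(=O)/C=C/c1cc(OC)c(OC)c(OC)c1` gives > 200 mg/kg, also a limit. Compound 3 `COc1cc(OC)c(OC)cc1/C=C/COC(=O)/C=C/c1ccc(OC)c(OC)c1OC` gives > 300 mg/kg, again a limit. Going by the values given here, no compound has yet given a number, so no measured step is available as a guide.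

Compound 4 `COc1ccc(/C=C/C(=O)OC/C=C/c2cc(OC)c(OC)cc2OC)cc1` keeps the core of compound 1 and carries methoxy in place of bromo on an aromatic carbon, para to a large group (methoxy in place of bromo on an aromatic carbon). Compound 2 and compound 3 both carry methoxy groups on that ring and still give only limits. In this assay, no step beyond the scatter is therefore expected, and no direction can be favoured. The estimated step is a number no higher from compound 1 to compound 4 (the limit leaves the size open). For compound 4 the expected value is 300 mg/kg, with an estimated range from 150 mg/kg to 600 mg/kg. A further limit rather than a number is the likelier report.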

Compound 4, dose for half-maximal effect: > 300 mg/kg
Compound 4 gave a limit, no number (the forecaster's own chance of this, stated with the estimate: 65%); the middle value lies on the limit itself.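

Compound 1 and compound 4 each give only a limit, and the step between them cannot be read. The compounds shown leave open whether methoxy in place of bromo changes the dose for half-maximal effect, and at what dose any of them would give a number: the limit of > 300 mg/kg in this assay, at which 3 of the 4 values shown sit.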